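Swapping One End Group on Two Related Cores

The source may hold more compounds than are shown below. What is called first, only, known or untested is meant among the compounds shown, and "the series" means these compounds.

Compound 1, `Cc1ccc2[nH]c(-c3ccc(-c4ccc(-c5cccc(Cl)c5)cc4)cc3)nc2c1`: in a functional assay on DWD cells (Homo sapiens) for inhibition, read by sulforhodamine B assay (on this read-out lower numbers stand for stronger inhibition of growth and higher numbers for weaker inhibition of growth), compound 1 gives 2510 nM.
Compound 2, `COc1ccc(-c2ccc(-c3ccc(-c4nc5cc(C)ccc5[nH]4)cc3)cc2)cc1OC`: compound 2 gives 1720 nM.
Compound 3, `Oc1cccc2[nH]c(-c3ccc(-c4ccc(-c5cccc(Cl)c5)cc4)cc3)nc12`: compound 3 gives 2100 nM.

Compound 2 differs from compound 1 in one place only: 3,4-dimethoxyphenyl in place of 3-chlorophenyl on an aromatic carbon. That change produced a 1.5-fold lower number from compound 1 to compound 2 (0.16 log units; within the scatter), so the two compounds cannot be told apart by this read-out.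

Compound 4, `COc1ccc(-c2ccc(-c3ccc(-c4nc5c(O)cccc5[nH]4)cc3)cc2)cc1OC`, has not yet been measured. It relates to compound 3 exactly as compound 2 relates to compound 1: 3,4-dimethoxyphenyl in place of 3-chlorophenyl on an aromatic carbon. The place is described in the same words in both cases. This is the same change, made a second time on a different core. How the core of compound 3 differs from the core of compound 1 is not broken down here; their two values lie within the scatter of each other.

The step from compound 3 to compound 4 is expected to be a 1.5-fold lower number from compound 3 to compound 4 (0.18 log units; within the scatter), because the same change gave a 1.5-fold lower number from compound 1 to compound 2 (0.16 log units; within the scatter). Compound 4 is therefore estimated at 1400 nM, with a range expected from 800 nM to 2600 nM.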

Compound 4, concentration for 50% growth inhibition: 1400 nM
Compound 4: the middle estimate sits on the measured number at the digits printed; the range from low to high includes it.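

In this assay, putting 3,4-dimethoxyphenyl in place of 3-chlorophenyl gave a 1.5-fold lower number from compound 3 to compound 4 (0.18 log units; within the scatter), and this step agrees with the earlier one: the same change on two cores in this assay, a 1.5-fold lower number (0.16 log units; within the scatter) from compound 1 to compound 2 and a 1.5-fold lower number (0.18 log units; within the scatter) from compound 3 to compound 4, 1.0-fold (0.01 log units) apart, within the scatter of two such steps.
Within the data shown here, each step lies within the scatter, so the agreement shows only that this change leaves the read-out indistinguishable on both cores; it does not show that a change with a clear effect would carry over from one core to the other. Keeping 3,4-dimethoxyphenyl and exchanging 5-methyl-1H-benzimidazol-2-yl for 4-hydroxy-1H-benzimidazol-2-yl gave a 1.2-fold lower number from compound 2 to compound 4 (0.09 log units; within the scatter), so these two cores cannot be told apart by this read-out either.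

Among these compounds, with only two end groups on two cores, it remains open whether steps that stand clear of the scatter would also match from core to core. An end group carrying an amine or a carboxylic acid, placed on both cores, would be one way to test this.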